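From propyl to 4-methoxyphenyl on a carbonyl carbon

This account rests on a few compounds, and the source may have more. Where it says the series, first, only, none or still open, it means among the compounds named here.

- compound 1 `CC(=O)O[C@H](C/C(C)=C/CO)[C@@]1(C)[C@H](C)CC=C2[C@@H]1CCCC2(C)C` gives > 30000 nM as a limit
- compound 2 `CCC(=O)OC/C=C(\C)C[C@@H](O)[C@@]1(C)[C@H](C)CC=C2[C@@H]1CCCC2(C)C` gives 24700 nM as a measured number
- compound 3 `CCCC(=O)OC/C=C(\C)C[C@@H](O)[C@@]1(C)[C@H](C)CC=C2[C@@H]1CCCC2(C)C` gives > 30000 nM as a limit

All three values come from a functional assay on U-937 cells (Homo sapiens) for cytotoxicity, read by MTT assay, with a stated time of 72 h (on this read-out lower numbers stand for stronger inhibition and higher numbers for weaker inhibition), and only one of them is a true number. Compound 3 shows > 30000 nM as a limit and not a number. Compound 3 shares the limit of > 30000 nM in this assay, at which 2 of the 3 values shown sit, with compound 1 and has no number of its own.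

In compound 4 `COc1ccc(C(=O)OC/C=C(\C)C[C@@H](O)[C@@]2(C)[C@H](C)CC=C3[C@@H]2CCCC3(C)C)cc1` a 4-methoxyphenyl stands in place of propyl on a carbonyl carbon (the difference from compound 3 is 4-methoxyphenyl in place of propyl on a carbonyl carbon). Going by the values given here, the one measured step that changes the group on this carbonyl carbon is an at least 1.2-fold higher number from compound 2 to compound 3 (0.08 log units; that floor lies within the scatter) and it adds only a methyl, with no ring, so it guides the estimate loosely. From that small step and from compound 2 at 24700 nM in the same series, no change beyond the scatter is expected. The expected step is an at least 1.2-fold lower number from compound 3 to compound 4 (0.07 log units; that floor lies within the scatter) with no firm direction. For compound 4 the estimated value is 25000 nM with an expected range from 9000 nM to 60000 nM and a reading at the limit would be no surprise.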

Compound 4, half-maximal inhibitory concentration: > 30000 nM
Compound 4: no number, only a limit; the forecaster's own chance of this, stated with the estimate: 50%; at least 1.2-fold (0.07 log units) between middle value and limit.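

Compound 4 also reads as a limit and not a number in this assay: the limit of > 30000 nM in this assay, at which 3 of the 4 values shown sit. Putting 4-methoxyphenyl in place of propyl on the carbonyl carbon adds an aromatic ring, yet it yields no measurable number, and the step between two limits cannot be read. Going by these compounds alone, the change from ethyl to 4-methoxyphenyl on this carbon gives an at least 1.2-fold higher number from compound 2 to compound 4 (0.08 log units; that floor lies within the scatter), so even the comparison with the one compound that has a true number shows no firm difference.

Going by these compounds, the true values of compound 3 and compound 4 stay unknown, so a propyl chain and a 4-methoxyphenyl ring cannot be ranked at this position. Also open, on these data alone, is whether an aminomethyl group or a carboxylic acid on this carbonyl carbon would give a clear number in this assay.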